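Series notes: furan-2-yl to 5-chloro-2-hydroxyphenyl

The source may hold more compounds than are shown below. What is called first, only, known or untested is meant among the compounds shown, and "the series" means these compounds.

Compound 1 `COc1ccc(C(=O)/C=C/c2ccco2)c2c1C=CC(C)(C)O2` gives only a limit, not a number, in a functional assay on HepG2 cells (Homo sapiens) for antiproliferative activity, read by MTT assay, with a stated time of 24 h (a lower number here means a stronger inhibitor, a higher number a weaker inhibitor), namely > 10000 nM. Compound 2 `COc1cc(/C=C/C(=O)c2ccc(OC)c3c2OC(C)(C)C=C3)cc(OC)c1O` likewise gives only a limit in this assay, > 10000 nM. Going by the values given here, both recorded values sit at the limit of > 10000 nM in this assay, at which 2 of the 2 values shown sit, so no measured step shows a direction, and compound 1 stands level with the only other measured compound. Compound 3 `COc1ccc(C(=O)/C=C/c2cc(Cl)ccc2O)c2c1C=CC(C)(C)O2` differs from compound 1 by 5-chloro-2-hydroxyphenyl in place of furan-2-yl on a double-bonded chain carbon bound to a double-bonded chain carbon. With nothing measured to lean on, the expected step that the limit leaves unreadable from compound 1 to compound 3 is small and likely within the scatter. Compound 3 is estimated at 15000 nM, with a range from 3000 nM to 60000 nM.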

Compound 3, half-maximal inhibitory concentration: 6640 nM
Compound 3: the middle estimate sits 2.3-fold (0.35 log units) above what was measured, and the stated range covers the measured number.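

Among the compounds shown, only the 5-chloro-2-hydroxyphenyl group on a double-bonded chain carbon bound to a double-bonded chain carbon gives a number rather than a limit in this assay: the limit of > 10000 nM in this assay, at which 2 of the 3 values shown sit.

The change reads as an at least 1.5-fold lower number from compound 1 to compound 3 (0.17 log units; that floor lies within the scatter). As far as these compounds go, that is only a floor, so the full size of the step remains unknown, and it cannot yet be called a real gain.

Open, from the compounds shown here alone, is whether the chlorine, the hydroxyl or the six-membered ring accounts for the step. A plain phenyl or a 2-hydroxyphenyl at this place would separate these.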